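Chloro for fluoro in a small growth-inhibition series

The source may hold more compounds than are shown below. What is called first, only, known or untested is meant among the compounds shown, and "the series" means these compounds.

- compound 1 `Cc1cc(C)c2c(O)cc(-c3ccc(Cl)cc3)nc2n1` gives 4070 nM
- compound 2 `Oc1cc(-c2ccc(Cl)cc2)nc2ncccc12` gives 5890 nM
- compound 3 `Cc1ccnc2nc(-c3ccc(F)cc3)cc(O)c12` gives 2880 nM

All values come from a functional assay on MDA-MB-435 cells (Homo sapiens); on this read-out lower numbers stand for stronger inhibition of growth and higher numbers for weaker inhibition of growth. Compound 3 at 2880 nM lies within the scatter of compound 1, while compound 2 stands beyond the scatter on the higher side of compound 3. Compound 4 `Cc1ccnc2nc(-c3ccc(Cl)cc3)cc(O)c12` carries chloro in place of fluoro on an aromatic carbon, para to a large group (chloro in place of fluoro on an aromatic carbon). For the measured compounds named here, no measured pair isolates this change, and compound 1 and compound 2, which also carry chloro, differ from compound 3 elsewhere too. No step beyond the scatter is therefore expected in this assay. The expected change is a 1.2-fold higher number from compound 3 to compound 4 (0.08 log units; within the scatter) (within the scatter). For compound 4 the estimated value is 3500 nM (range 1700 nM to 7000 nM).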

Compound 4, concentration for 50% growth inhibition: 759 nM
Compound 4: the middle estimate sits 4.6-fold (0.66 log units) above what was measured, and the stated range ends above it.
By their numbers in this assay, from the lowest: compound 4; then compounds 3, 1 and 2 (each within the scatter of the next, the first and the last beyond it).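

In this assay, chloro in place of fluoro on this aromatic carbon, para to a large group, is not a neutral swap (  a 3.8-fold lower number from compound 3 to compound 4 (0.58 log units; beyond the scatter)). The methyl count on the shared core matters too: methyl in place of hydrogen lowers the number (a 7.8-fold lower number from compound 2 to compound 4 (0.89 log units; beyond the scatter)), and so does hydrogen in place of methyl (a 5.4-fold lower number from compound 1 to compound 4 (0.73 log units; beyond the scatter)), leaving the single-methyl compound 4 below both compound 1 and compound 2.

Going by these compounds, whether bromo or methoxy at this position would lower the number further remains open. Nothing available explains these steps.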